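Swapping Fluoro for Hydroxy on a Fused Core

The source may report more compounds than this note shows. Statements on the series, on what has been measured and on what is new or still open speak of the compounds shown alone.

Of the compounds shown here, two that share a core have been measured in a functional assay on HCT-8 cells (Homo sapiens) for cytotoxicity; on this read-out higher numbers stand for an effect only at larger amounts of compound and lower numbers for an effect already at smaller amounts. Compound 1, `Oc1cc(-c2ccccc2)nc2cc(F)ccc12`, gives 3.45 ug/mL in this assay. Compound 2, `Oc1cc(-c2ccccc2)nc2ccc(Cl)cc12`, gives 0.7 ug/mL in this assay. Of these two numbers, compound 1 stands at the higher one, and the gap to compound 2 is beyond the usual scatter of repeated measurements, so compound 2 acts at the smaller amount of the two.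

Compound 3, `Oc1ccc2c(O)cc(-c3ccccc3)nc2c1`, has not yet been measured. Compared with compound 1 it differs in one place: hydroxy in place of fluoro on an aromatic carbon. Within the data shown here, the data hold no measured pair that shows what such a swap does on this core, so the direction of the step is open. A change of this kind is expected to stay close to the starting value, with a step of a 1.3-fold higher number from compound 1 to compound 3 (0.12 log units; within the scatter) estimated in this assay, which is no more than the usual scatter. Compound 3 is therefore estimated to give 4.5 ug/mL in this assay, with a likely range from 1.5 ug/mL to 14 ug/mL.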

Compound 3, half-maximal effective concentration: > 10 ug/mL
Compound 3: only a limit was reported (the forecaster's own chance of this, stated with the estimate: 5%); middle value at least 2.2-fold (0.34 log units) away from the limit.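

In this assay compound 3 gives > 10 ug/mL, which is a limit of the assay and not a number. Hydroxy in place of fluoro on an aromatic carbon, at the place meta to a fused ring and para to a fused ring, is the first single change on the shared core that can be read, and it comes with an at least 2.8-fold higher number from compound 1 to compound 3 (0.46 log units; beyond the scatter), so this one swap moves the effect to larger amounts of compound by more than repeated measurements would scatter. How far the step really reaches cannot be read, and this is the only such value among the compounds shown: the limit of > 10 ug/mL in this assay, at which 1 of the 3 values shown sits.

The compounds shown leave open whether the shift belongs to the incoming hydroxy or to the loss of the fluoro, and why it happens, since a single swap at a single place cannot separate the two. An amine or a methoxy group at this same place, or a bare hydrogen there, would show whether any group other than fluoro on this carbon moves the number the same way.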